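The source may hold more compounds than are shown below. What is called first, only, known or untested is meant among the compounds shown, and "the series" means these compounds.

Measured in an ADME assay on the whole organism (Rattus norvegicus, strain Wistar Han) for pharmacokinetics, read by LC-MS, with stated times of 1 h and 7 h, at a dose of 1 mg/kg by the intravenous route; a higher number here means faster removal of the compound, a lower number slower removal:
- compound 1 `CNC(=O)c1cc(C(=O)N[C@@H]2C[C@H]2CO)cc2c1O[C@H](CF)[C@H]2c1ccccc1`: 4 mL/min/kg
- compound 2 `CNC(=O)c1cc(C(=O)NC2CC2)cc2c1O[C@H](CO)[C@H]2c1ccccc1`: 23 mL/min/kg

Compound 2 stands highest of these two at 23 mL/min/kg, a gap to compound 1 at 4 mL/min/kg that lies beyond the scatter. Compound 3 `CNC(=O)c1cc(C(=O)NC2CC2)cc2c1O[C@H](C)[C@H]2c1ccccc1` departs from compound 2 by hydrogen in place of hydroxy on a saturated chain carbon bound to a saturated ring carbon, with hydrogen in place of hydroxy on a saturated chain carbon bound to a saturated ring carbon. Going by the values given here, no measured pair shows this change alone, so the expectation is tentative. The expected change is a small rise in this assay, not beyond the scatter, estimated as a 1.3-fold higher number from compound 2 to compound 3 (0.12 log units; within the scatter). The estimate for compound 3 is 30 mL/min/kg, with an expected range of 13 mL/min/kg to 65 mL/min/kg.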

Compound 3, clearance in the Rattus norvegicus assay: 0.2 mL/min/kg
For compound 3 the middle estimate is 150-fold (2.18 log units) above the measured one, and the stated range ends above it.
By their numbers in the Rattus norvegicus assay, from the lowest: compound 3; then compound 1; then compound 2.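

Going by these compounds alone, in the Rattus norvegicus assay, hydrogen in place of hydroxy on a saturated chain carbon bound to a saturated ring carbon gives a 120-fold lower number from compound 2 to compound 3 (2.06 log units; beyond the scatter), the first single-change reading at this position, and it shows that this one change alone can move removal strongly. In a physicochemical assay for solubility (a higher number here means a more soluble compound, a lower number a less soluble compound), the same change reads an at least 1.2-fold lower number from compound 2 to compound 3 (0.11 log units; that floor lies within the scatter), a floor within the scatter, so no drop is shown. In the physicochemical assay compound 2 gives > 177 ug/mL, which is a limit and not a number. In the physicochemical assay compound 3 gives 137 ug/mL. The floor rests on the limit for compound 2: the limit of > 177 ug/mL in the physicochemical assay, at which 1 of the 2 values shown sits.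

Nothing shown bears on why removal falls so far. From the compounds shown here alone, whether an amine or a longer chain at this place would also give slow removal remains open.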